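A Dinitrophenyl Swap at the Cytotoxicity Limit

This account rests on a few compounds, and the source may have more. Where it says the series, first, only, none or still open, it means among the compounds named here.

In an ADME assay on HEK-293T cells (Homo sapiens) for cytotoxicity, read by CCK-8 assay, with a stated time of 48 h (on this read-out higher numbers stand for weaker inhibition and lower numbers for stronger inhibition), compound 1 (`O=C(NCCNS(=O)(=O)c1ccc(-c2ccccc2OCc2cccc(O)c2)s1)Nc1cc(C(F)(F)F)cc(C(F)(F)F)c1`) reads > 20000 nM as a limit of the assay, not a number. Compound 2 (`COc1ccc(NC(=S)NCCNS(=O)(=O)c2sccc2-c2ccc(C)cc2Oc2ccc(O)c(O)c2)cc1`) gives > 20000 nM as a limit too. Compound 3 (`COc1ccc(Oc2ccccc2-c2ccsc2S(=O)(=O)N2CCN(C(=O)Nc3cc(C(F)(F)F)cc(C(F)(F)F)c3)CC2)cc1OC`) also gives > 20000 nM as a limit. Compound 1 therefore has no exact place on the scale, only a place alongside the other two measured compounds.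

The next compound to be tested is compound 4 (`O=C(NCCNS(=O)(=O)c1ccc(-c2ccccc2Oc2ccc([N+](=O)[O-])c([N+](=O)[O-])c2)s1)Nc1cc(C(F)(F)F)cc(C(F)(F)F)c1`). It carries 3,4-dinitrophenyl in place of 3-hydroxybenzyl on an oxygen on an aromatic ring. Going by the values given here, no measured pair of compounds differing in a single place is available to show how large such a change tends to be in this assay and so the forecast has to stay cautious. The expected step, a number no higher from compound 1 to compound 4 (the limit leaves the size open) and no more, is none beyond the usual scatter of such measurements. That expectation rests on compound 1 with its > 20000 nM reading as a limit and on the overall picture, the limit of > 20000 nM in this assay, at which 3 of the 3 values shown sit, and no measured exception to it.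

For compound 4 the estimated value is 20000 nM in a range from 8000 nM to 40000 nM and the assay may well report only a limit again.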

Compound 4, half-maximal inhibitory concentration: > 50000 nM
Compound 4: no number, only a limit; the forecaster's own chance of this, stated with the estimate: 75%; middle value at least 2.5-fold (0.39 log units) from the limit.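

In this assay, going by these compounds alone, compound 1 and compound 4 both read only as limits of the assay, not as numbers, so no step between them can be read. The compounds shown leave open how large a change, if any, 3,4-dinitrophenyl in place of 3-hydroxybenzyl brings, and none of them gives an exact value on this scale.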